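The source may report more compounds than this note shows. Statements on the series, on what has been measured and on what is new or still open speak of the compounds shown alone.

Measured in a functional assay on NCI-H460 cells (Homo sapiens) for cytotoxicity, read by MTT assay, with a stated time of 72 h; a lower number here means a stronger inhibitor, a higher number a weaker inhibitor:
- compound 1 `CCN(CC)Cc1ccc2nc(NC(=O)N/N=C/c3c[nH]c4ccccc34)sc2c1`: 3140 nM
- compound 2 `CCN(CC)Cc1ccc2nc(NC(=O)N/N=C/c3cn(Cc4ccccc4)c4ccccc34)sc2c1`: 450 nM
- compound 3 `CN(C)Cc1ccc2nc(NC(=O)N/N=C/c3cn(Cc4ccc(Cl)c(Cl)c4)c4ccccc34)sc2c1`: 1360 nM

Compound 3 holds the second highest of the three numbers, closest to compound 1 and furthest from compound 2. Compound 4 `CCN(CC)Cc1ccc2nc(NC(=O)N/N=C/c3cn(Cc4ccc(Cl)c(Cl)c4)c4ccccc34)sc2c1`, not yet measured, differs from it by diethylamino in place of dimethylamino on a saturated chain carbon bound to an aromatic carbon. Within the data shown here, the only measured single change, a 7.0-fold lower number from compound 1 to compound 2 (0.84 log units; beyond the scatter), is benzyl in place of hydrogen on an aromatic nitrogen and leaves this group untouched. Among the measured compounds shown here, no measured step therefore covers the change. Compound 2 also carries diethylamino, but differs from compound 3 elsewhere too. No step beyond the scatter is expected in this assay, with a slight lean towards a lower number. The estimated step is a 1.5-fold lower number from compound 3 to compound 4 (0.18 log units; within the scatter). For compound 4 the expected value is 900 nM, with an estimated range of 380 nM to 2100 nM.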

Compound 4, half-maximal inhibitory concentration: 610 nM
Compound 4: the middle estimate sits 1.5-fold (0.17 log units) above what was measured; the measured number falls inside the stated range.
By their numbers in this assay, from the lowest: compounds 2 and 4 (each within the scatter of the next); then compound 3; then compound 1.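

In this assay, the amine on the saturated chain carbon bound to an aromatic carbon now has a step of its own (a 2.2-fold lower number from compound 3 to compound 4 (0.35 log units; beyond the scatter)), so diethylamino in place of dimethylamino registers with the 3,4-dichlorobenzyl group held fixed. With diethylamino held fixed, 3,4-dichlorophenyl in place of phenyl gives only (a 1.4-fold higher number from compound 2 to compound 4 (0.13 log units; within the scatter)), while 3,4-dichlorobenzyl in place of hydrogen on the aromatic nitrogen gives (a 5.1-fold lower number from compound 1 to compound 4 (0.71 log units; beyond the scatter)). No evidence on the cause of the amine step is available.

Open, as far as these compounds go, is whether pyrrolidine or morpholine in place of diethylamino would extend this step. Also open, from the compounds shown here alone, is whether the same amine step holds with plain benzyl on the aromatic nitrogen.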